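The source may report more compounds than this note shows. Statements on the series, on what has been measured and on what is new or still open speak of the compounds shown alone.

Measured compounds in this series:
- compound 1 `COc1cc(C2CC(c3ccc(Br)cc3)=NN2C(C)=O)cc(OC)c1OC`: 3450 nM
- compound 2 `COc1cc(C2CC(c3ccco3)=NN2C(C)=O)cc(OC)c1OC`: 9650 nM
- compound 3 `COc1ccc(C2CC(c3ccco3)=NN2C(C)=O)cc1OC`: 12300 nM

In a functional assay on PC-3 cells (Homo sapiens) for cytotoxicity, read by sulforhodamine B assay, with a stated time of 48 h (on this read-out higher numbers stand for weaker inhibition and lower numbers for stronger inhibition), compound 2 gives 9650 nM, the second highest of the three numbers. Compound 3 sits nearest, with a 1.3-fold higher number from compound 2 to compound 3 (0.11 log units; within the scatter), a gap that stays within the scatter. Compound 1 stands furthest away and is the only one of the three that differs from compound 2 beyond the scatter, with a 2.8-fold higher number from compound 1 to compound 2 (0.45 log units; beyond the scatter).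

Compound 4 `COc1cc(C2CC(c3cccc4ccccc34)=NN2C(C)=O)cc(OC)c1OC` is not yet measured. It differs from compound 2 by one change: naphthalen-1-yl in place of furan-2-yl on a carbon with a double bond to nitrogen.

Among the compounds with values here, of the measured steps, only the one from compound 1 to compound 2 touches the same carbon and swaps the same kind of group, an aryl on the carbon with a double bond to nitrogen; that step was modest, a 2.8-fold higher number from compound 1 to compound 2 (0.45 log units; beyond the scatter). Going from the furan-2-yl back to a carbon-only aromatic group is therefore expected to move the number downward by a comparable, modest amount, a 2.1-fold lower number from compound 2 to compound 4 (0.33 log units; beyond the scatter). Compound 4 is estimated at 4500 nM in this assay, with a range of 1500 nM to 13000 nM.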

Compound 4, half-maximal inhibitory concentration: 1090 nM
The estimate for compound 4 lay 4.1-fold (0.62 log units) above the measured number, and the stated range ends above it.
By their numbers in this assay, from the lowest: compound 4; then compound 1; then compounds 2 and 3 (each within the scatter of the next).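

In this assay, within the data shown here, the aryl group on the carbon with a double bond to nitrogen has a wider reach than the earlier compounds showed: the change from furan-2-yl gives an 8.9-fold lower number from compound 2 to compound 4 (0.95 log units; beyond the scatter), and the change from 4-bromophenyl still gives a 3.2-fold lower number from compound 1 to compound 4 (0.50 log units; beyond the scatter). At this carbon, on the shared core, the numbers rise from naphthalen-1-yl through 4-bromophenyl to furan-2-yl, so the 4-bromophenyl value no longer marks the low end for the series. Nothing available explains why this position responds in this way.

Going by these compounds, it remains open whether an unsubstituted phenyl, a naphthalen-2-yl or a quinoline, with a ring nitrogen, would follow this order. On these data alone, it is also open whether naphthalen-1-yl keeps its place on the core of compound 3, which has one methoxy fewer.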